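Para substituent swap on the shared core, methyl for chloro

This account rests on a few compounds, and the source may have more. Where it says the series, first, only, none or still open, it means among the compounds named here.

The series shares one core and varies the group on the aromatic ring. Compound 1 `O=C1CC2(CO1)CSC(=S)N2c1ccc(F)cc1` was tested in a functional assay on HeLa cells (Homo sapiens) for antiproliferative activity, read by MTT assay, with a stated time of 72 h; on this read-out higher numbers stand for weaker inhibition and lower numbers for stronger inhibition. In this assay compound 1 gives > 50 ug/mL, which is a limit of the assay rather than a number. Compound 2 `O=C1CC2(CO1)CSC(=S)N2c1ccc(Cl)cc1` in this assay gives > 50 ug/mL, again a limit. The step that the two limits leave unreadable from compound 1 to compound 2 therefore has no readable size. the limit of > 50 ug/mL in this assay, at which 2 of the 2 values shown sit, is all the evidence on the measured steps. Compound 3 `Cc1ccc(N2C(=S)SCC23COC(=O)C3)cc1` is not yet measured; it differs from compound 2 by methyl in place of chloro on an aromatic carbon. Within the data shown here, the one measured step at this position bears on the change but gives neither size nor direction. The expectation for compound 3 rests on compound 2 giving > 50 ug/mL, a limit. Compound 3 is expected to give 50 ug/mL (range 20 ug/mL to 100 ug/mL) in this assay, most likely reported again as a limit. The step of a number no higher from compound 2 to compound 3 (the limit leaves the size open) that this estimate means is expected to stay within the scatter.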

Compound 3, half-maximal inhibitory concentration: > 50 ug/mL
Compound 3: no number, only a limit; the forecaster's own chance of this, stated with the estimate: 80%; the middle value lies on the limit itself.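

Compound 3 also gives only a limit in this assay, so no step among compound 1, compound 2 and compound 3 can be read: the limit of > 50 ug/mL in this assay, at which 3 of the 3 values shown sit.

The compounds shown leave open whether fluoro, chloro and methyl on the aromatic ring differ at all in this assay.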